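Benzyl variation on the shared core: toward compound 4

A few compounds are considered here, and "the series" means these few. Any claim that something is new, unique, unknown or untested is made for them only; others in the source may bear on it.

Measured in a functional assay on L1210 cells (Mus musculus) for inhibition, read by cell counting, with a stated time of 2 days; on this read-out lower numbers stand for stronger inhibition and higher numbers for weaker inhibition:
- compound 1 `C=C(Br)C(=O)Nc1cccc(-c2cn3nc(Cc4cccc(OC)c4)sc3n2)c1`: 2000 nM
- compound 2 `Nc1cccc(-c2cn3nc(CCc4ccccc4)sc3n2)c1`: 31000 nM
- compound 3 `Nc1cccc(-c2cn3nc(Cc4ccc(Cl)cc4)sc3n2)c1`: 16000 nM

Compound 3 sits second highest of the three numbers in this assay. Among the compounds with values here, its nearest neighbour is compound 2, and the step of a 1.9-fold lower number from compound 2 to compound 3 (0.29 log units; within the scatter) is the only single-point change measured so far; it stays within the scatter. Within the data shown here, compound 1, which carries a 3-methoxybenzyl group together with an acrylamide on the aniline nitrogen, gives a lower number than compound 3, beyond the scatter, but it differs from compound 3 in two places and no single step connects them.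

Compound 4 `COc1cccc(Cc2nn3cc(-c4cccc(N)c4)nc3s2)c1` is not yet measured. The change from compound 3 is 3-methoxyphenyl in place of 4-chlorophenyl on a saturated chain carbon bound to an aromatic carbon. Among the measured compounds shown here, the one step that bears on it, a 1.9-fold lower number from compound 2 to compound 3 (0.29 log units; within the scatter), shows that swapping the aryl group on the benzylic carbon moved the number little. An equally small step is therefore expected here, a 1.3-fold lower number from compound 3 to compound 4 (0.12 log units; within the scatter), with no direction beyond the scatter. Compound 4 is estimated at 12000 nM in this assay, with a range from 4000 nM to 40000 nM.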

Compound 4, half-maximal inhibitory concentration: 21000 nM
For compound 4 the middle estimate is 1.8-fold (0.24 log units) below the measured one; low and high end bracket the measured number.
By their numbers in this assay, from the lowest: compound 1; then compounds 3, 4 and 2 (each within the scatter of the next).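

In this assay, the 3-methoxyphenyl group on a saturated chain carbon bound to an aromatic carbon stays within the scatter of both other aryl variants, with a 1.3-fold higher number from compound 3 to compound 4 (0.12 log units; within the scatter) and a 1.5-fold lower number from compound 2 to compound 4 (0.17 log units; within the scatter), so across compounds 2, 3 and 4 the change at this position produces no step beyond the scatter. Within the data shown here, the one clear step lies at the other place, on a nitrogen on an aromatic ring, where hydrogen in place of (1-bromoethenyl)carbonyl gives an 11-fold higher number from compound 1 to compound 4 (1.02 log units; beyond the scatter). No available evidence accounts for either result.

From the compounds shown here alone, the (1-bromoethenyl)carbonyl group appears here with the 3-methoxyphenyl group only, so whether the same step holds with the other aryl variants remains open. Also open, going by these compounds, is how a plain acetyl on that nitrogen, or a carboxylic acid on the aryl ring, would read.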